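Swapping a cyanobenzyl arm for a tert-butylphenoxy arm

This account rests on a few compounds, and the source may have more. Where it says the series, first, only, none or still open, it means among the compounds named here.

Compound 1 `CC(C)(C)c1ccc(Oc2ccc3c(NCCCNCc4ccco4)ccnc3c2)cc1`: 9.28
Compound 2 `COc1cccc(CNCCCNc2ccnc3cc(Oc4ccccc4)ccc23)c1O`: 9.28
Compound 3 `COc1cccc(CNCCCNc2ccnc3cc(Cc4ccc(C#N)cc4)ccc23)c1O`: 9.47

In a physicochemical assay for acid dissociation, compound 3 gives 9.47; the other two measured numbers both lie within the scatter of it, so the three compounds cannot be told apart. Compound 4 `COc1cccc(CNCCCNc2ccnc3cc(Oc4ccc(C(C)(C)C)cc4)ccc23)c1O` differs from compound 3 by 4-(tert-butyl)phenoxy in place of 4-cyanobenzyl on an aromatic carbon. Within the data shown here, one measured step touches the same position: a number 0.19 log units higher from compound 2 to compound 3 (within the scatter), which stayed within the scatter. Compound 1 already carries the entering group, with a different amine arm, and gives 9.28, again within the scatter of compound 3. Nothing here points to a step beyond the scatter. Compound 4 is therefore expected at 9.3, within a range of 9 to 9.6. That amounts to an expected step of a number 0.17 log units lower from compound 3 to compound 4 (within the scatter).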

Compound 4, acid dissociation constant: 9.28
Compound 4: the middle estimate sits 0.02 log units above what was measured, within the range that was stated.
By their numbers in this assay, from the lowest: compounds 1, 2, 4 and 3 (each within the scatter of the next).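

In this assay, the exchange of 4-cyanobenzyl for 4-(tert-butyl)phenoxy on this aromatic carbon gives a number 0.19 log units lower from compound 3 to compound 4 (within the scatter) and so does not separate the two groups. Adding tert-butyl to the phenoxy ring gives no change at the digits printed from compound 2 to compound 4 (within the scatter) and placing 2-hydroxy-3-methoxyphenyl where furan-2-yl stood gives no change at the digits printed from compound 1 to compound 4 (within the scatter) so neither change separates these compounds either. Nothing available explains why the numbers stay so close. Still open, going by these compounds, is whether an amine or a carboxylic acid on this aromatic carbon would give a step beyond the scatter.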